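Heteroaryl thioether variation on a shared acetamide core

The source may report more compounds than this note shows. Statements on the series, on what has been measured and on what is new or still open speak of the compounds shown alone.

Measured so far:
compound 1 `Cn1nnnc1SCC(=O)Nc1ccc(-c2nc(-c3ccccc3)c(-c3ccccc3)n2C)cc1` — 84%
compound 2 `Cc1nnc(SCC(=O)Nc2ccc(-c3nc(-c4ccccc4)c(-c4ccccc4)n3C)cc2)s1` — 87.1%

In a functional assay on HT-29 cells (Homo sapiens) for cytotoxicity, read by MTT assay, with a stated time of 24 h, tested at 32 ug/mL (on this read-out lower numbers stand for a weaker effect and higher numbers for a stronger effect at the one concentration tested), compound 1 gives 84%, and compound 2 gives 87.1%. Among the measured compounds shown here, the one step between them, a number 3.1 percentage points higher from compound 1 to compound 2 (within the scatter), is within the scatter, so compound 2 stands level with compound 1 on the two numbers available; no difference in effect between them can be claimed.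

Compound 3 `Cn1ccnc1SCC(=O)Nc1ccc(-c2nc(-c3ccccc3)c(-c3ccccc3)n2C)cc1` is the next member. Its change from compound 2 is 1-methyl-1H-imidazol-2-yl in place of 5-methyl-1,3,4-thiadiazol-2-yl on a sulfur. For the measured compounds named here, the only comparison that bears on this position is the step from compound 1 to compound 2, where one five-membered heteroaryl group on the sulfur gave way to another with no movement beyond the scatter. Compound 3 again swaps one small five-membered heteroaryl group on the same sulfur for another, so no step beyond the scatter is expected in this assay either, in neither direction, and the expected change a number 2.1 percentage points lower from compound 2 to compound 3 (within the scatter) is taken as flat.

Compound 3 is therefore estimated at 85%, within 72% to 95%.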

Compound 3, a percentage reported as activity, at one concentration (the size of the read-out at that concentration, not a potency): 41.1%
Compound 3: the middle estimate sits 43.9 percentage points above what was measured; the measured number lies below the stated range.
By their numbers in this assay, from the lowest: compound 3; then compounds 1 and 2 (each within the scatter of the next).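

This position on the sulfur is not as tolerant as the first pair suggested: in this assay, 1-methyl-1H-imidazol-2-yl in place of 5-methyl-1,3,4-thiadiazol-2-yl gives a number 46 percentage points lower from compound 2 to compound 3 (beyond the scatter), and the same group in place of 1-methyl-1H-tetrazol-5-yl gives a number 42.9 percentage points lower from compound 1 to compound 3 (beyond the scatter). Since the groups leaving and entering in the first of these steps have the same heavy-atom count and each is one five-membered aromatic ring, those shared features alone do not keep the read-out high, and the identity of the heteroaryl group matters among these three compounds, with compound 3 the only one that departs from the other two. No measurement at hand accounts for this fall.

Open, as far as these compounds go, is how a six-membered ring such as pyridin-2-yl, or a non-aromatic group such as an ethyl chain, on the same sulfur would read in this assay, and so whether compound 3 is a lone low point or part of a wider trend. With a single concentration behind each number, the potency of these compounds relative to one another also remains open.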